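The compounds below may be only part of what the source reports. "The series", "measured", "known", "first", "only" and "open" are said of these compounds alone.

Three compounds have been measured in a functional assay on KM12 cells (Homo sapiens) for inhibition, read by sulforhodamine B assay, with a stated time of 48 h; a lower number here means a stronger inhibitor of growth, a higher number a weaker inhibitor of growth:

Compound 1 `COc1ccc(-c2cc(/C=C/C(=O)c3ccc(N)cc3)[nH]n2)cc1` gives 1540 nM.
Compound 2 `COc1ccc(C(=O)/C=C/c2cc(-c3cc(OC)c(OC)c(OC)c3)n[nH]2)cc1` gives 1560 nM.
Compound 3 `COc1cc(-c2cc(/C=C/C(=O)c3ccc(F)c(F)c3)[nH]n2)cc(OC)c1OC` gives 3060 nM.

Compound 1 has the lowest number of the three, yet its gap to compound 2 is negligible and its gap to compound 3 stays within the scatter, so the three compounds cannot be ranked against one another on these numbers.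

Compound 4 `COc1ccc(-c2cc(/C=C/C(=O)c3ccc(N)cc3)[nH]n2)cc1OC` is built from compound 1 by one change: methoxy in place of hydrogen on an aromatic carbon. The new methoxy group sits ortho to a methoxy group and meta to a large group on the ring attached to the shared core.

Going by the values given here, the only measured single step, a 2.0-fold higher number from compound 2 to compound 3 (0.29 log units; within the scatter), swaps the aryl group on the carbonyl carbon and so touches a different part of the molecule; it says nothing direct about adding a methoxy group to the other aryl ring. Compound 1 and compound 2 carry different numbers of methoxy groups on that ring, but they also differ at the carbonyl side, so their near-identical values only hint that the methoxy pattern there matters little. The expectation is therefore a step of a 1.0-fold lower number from compound 1 to compound 4 (0.01 log units; within the scatter) that does not exceed the scatter in this assay. For compound 4 the estimated value is 1500 nM, expected to lie between 700 nM and 3500 nM.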

Compound 4, concentration for 50% growth inhibition: 1680 nM
The estimate for compound 4 lay 1.1-fold (0.05 log units) below the measured number, and the stated range covers the measured number.
By their numbers in this assay, from the lowest: compounds 1, 2, 4 and 3 (each within the scatter of the next).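

In this assay, placing methoxy in place of hydrogen on an aromatic carbon, ortho to a methoxy group and meta to a large group, gives a 1.1-fold higher number from compound 1 to compound 4 (0.04 log units; within the scatter). Until now, the only hint about the methoxy groups on this ring came from comparing compound 1 and compound 2, a pair that also differs at the carbonyl side, whereas this pair differs in one place only. The result therefore shows directly that, with the rest of compound 1 held fixed, this position accepts a methoxy group without a change that can be told apart from the scatter. Nothing measured here speaks to the reason for this result.

The compounds shown leave open whether a different group at this same position, such as an amine, a carboxylic acid or a longer chain, would also leave the number within the scatter. They also leave open whether this methoxy step would read the same with 3,4-difluorophenyl or 4-methoxyphenyl on the carbonyl carbon.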